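The compounds below may be only part of what the source reports. "The series", "measured", "known", "first", "only" and "open" are said of these compounds alone.

Working notes on the series. Compound 1 `O=C(NCc1ccc(OCc2ccccc2)cc1)n1cccn1` gives 900 nM in an assay on membranes from brain for binding affinity to Monoglyceride lipase (Mus musculus), read by fluorescence, with stated times of 1 h and 30 min; on this read-out higher numbers stand for weaker inhibition and lower numbers for stronger inhibition. Compound 2 `N#Cc1cnn(C(=O)NCc2ccc(OCc3ccccc3)cc2)c1` keeps the core of compound 1 and differs only by cyano in place of hydrogen on an aromatic carbon; in this assay compound 2 gives 100 nM, so the change made a 9.0-fold lower number from compound 1 to compound 2 (0.95 log units; beyond the scatter). Compound 3 `O=C(N1CCN(C(c2ccc(OCc3ccccc3)cc2)c2ccc(OCc3ccccc3)cc2)CC1)n1cccn1` has a different core, and the difference between the two cores is not broken down here. In this assay compound 3 gives 3900 nM, the highest number of the three measured, set apart from compound 1 and compound 2 by steps beyond the scatter. Compound 4 `N#Cc1cnn(C(=O)N2CCN(C(c3ccc(OCc4ccccc4)cc3)c3ccc(OCc4ccccc4)cc3)CC2)c1` is not yet measured; it differs from compound 3 by cyano in place of hydrogen on an aromatic carbon, the same kind of change as from compound 1 to compound 2, at a place described in identical words. Among the compounds shown this change occurs twice in all, and only one instance is measured. Resting on the step of a 9.0-fold lower number from compound 1 to compound 2 (0.95 log units; beyond the scatter), the expected step is a 6.5-fold lower number from compound 3 to compound 4 (0.81 log units; beyond the scatter), held somewhat smaller since it is a single precedent on a different core. Compound 4 is estimated at 600 nM, expected to fall between 200 nM and 2000 nM.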

Compound 4, half-maximal inhibitory concentration: 20 nM
Compound 4: middle estimate off by 30-fold (1.48 log units), on the high side; measured number outside the range, below it.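

In this assay, cyano in place of hydrogen on an aromatic carbon again lowers the number on the second core, giving a 200-fold lower number from compound 3 to compound 4 (2.29 log units; beyond the scatter). The direction of the change carries from one core to the other, but its size does not: the same change on two cores in this assay, a 9.0-fold lower number (0.95 log units; beyond the scatter) from compound 1 to compound 2 and a 200-fold lower number (2.29 log units; beyond the scatter) from compound 3 to compound 4, 22-fold (1.34 log units) apart, beyond the scatter of two such steps. With a single step on each core, this shows that in these four compounds the step read on one core is no measure of its size on the other, but it does not show which part of the cores sets the size or how the change would read on any further core.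

The compounds shown carry only 1H-pyrazol-1-yl and 4-cyano-1H-pyrazol-1-yl, so it stays open whether another group at that place on the ring, such as a carboxylic acid, an amine or a trifluoromethyl, would follow the same direction on both cores. Also open, on these data alone, is how the same change would read on the core of compound 1 with a longer chain.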